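A few compounds are considered here, and "the series" means these few. Any claim that something is new, unique, unknown or untested is made for them only; others in the source may bear on it.

Compound 2 `COc1cccc(CNCCCNc2ccnc3cc(C4CCCCC4)ccc23)c1O` gives 4200 nM in a physicochemical assay for solubility, with a stated time of 18 h, at pH 7.4 (on this read-out lower numbers stand for lower solubility and higher numbers for higher solubility), the lowest of the two numbers measured; its nearest neighbour is compound 1 `COc1ccc(-c2ccc3c(NCCCNCc4cccc(OC)c4O)ccnc3c2)cc1`, which gives 32000 nM. Going by the values given here, the one measured step, a 7.6-fold lower number from compound 1 to compound 2 (0.88 log units; beyond the scatter), saw cyclohexyl replace 4-methoxyphenyl. Compound 3 `COc1cccc(CNCCCNc2ccnc3cc(-c4ccc(C(C)(C)C)cc4)ccc23)c1O` differs from compound 2 by 4-(tert-butyl)phenyl in place of cyclohexyl on an aromatic carbon. Among the compounds with values here, that step is the reverse kind of change, an aromatic ring returning, but it carries a tert-butyl rather than a methoxy group, so no measured step settles its direction. For compound 3 a small fall, a 2.1-fold lower number from compound 2 to compound 3 (0.32 log units; beyond the scatter), is expected, giving an estimated 2000 nM within the range 400 nM to 10000 nM.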

Compound 3, solubility: 32000 nM
The estimate for compound 3 lay 16-fold (1.20 log units) below the measured number, outside the stated range (above it).
By their numbers in this assay, from the lowest: compound 2; then compounds 1 and 3 (each within the scatter of the next).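

Putting 4-(tert-butyl)phenyl in place of cyclohexyl on this aromatic carbon gives a 7.6-fold higher number from compound 2 to compound 3 (0.88 log units; beyond the scatter) in this assay and shows that the earlier step can be reversed with a different aromatic group. Tert-butyl in place of methoxy gives no change at the digits printed from compound 1 to compound 3 (within the scatter) and so, across these three compounds, the number follows the aromatic ring rather than the group it carries. Nothing measured here gives a reason for this pattern. As far as these compounds go, whether the pattern extends to a phenyl ring carrying an amine or a carboxylic acid remains open.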